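A few compounds are considered here, and "the series" means these few. Any claim that something is new, unique, unknown or untested is made for them only; others in the source may bear on it.

Measured in a functional assay on SW982 cells (Homo sapiens) for inhibition, read by MTT assay, with a stated time of 72 h; on this read-out higher numbers stand for weaker inhibition and lower numbers for stronger inhibition:

- compound 1 `COc1cc(OC)c(OC)cc1/C=C/C(=O)c1ccccc1`: > 150000 nM (a limit)
- compound 2 `COc1cc(OC)c(OC)cc1/C=C/C(=O)c1cc(Cl)ccc1O`: > 150000 nM (a limit)
- compound 3 `COc1cc(OC)c(OC)cc1/C=C/C(=O)c1ccc(C)cc1`: 81100 nM

Within the data shown here, compound 3 holds the only true number in this small set. The other two compounds sit at the limit of > 150000 nM in this assay, at which 2 of the 3 values shown sit.

The next compound to be tested is compound 4 `COc1cc(OC)c(OC)cc1/C=C/C(=O)c1ccc(Br)cc1`. It differs from compound 3 by bromo in place of methyl on an aromatic carbon, which is bromo in place of methyl on an aromatic carbon, para to a large group. The closest measured change at an aromatic carbon is an at least 1.8-fold lower number from compound 1 to compound 3 (0.26 log units; that floor lies within the scatter), with methyl in place of hydrogen. A broader change, 4-methylphenyl in place of 5-chloro-2-hydroxyphenyl on a carbonyl carbon, gives an at least 1.8-fold lower number from compound 2 to compound 3 (0.26 log units; that floor lies within the scatter). Among the measured compounds shown here, both sizes are only floors, and no measured step exchanges methyl for bromo. These steps therefore give no firm basis for expecting a clear move in either direction in this assay.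

The expected result is a 1.2-fold lower number from compound 3 to compound 4 (0.06 log units; within the scatter), so no shift beyond the scatter is anticipated. For compound 4 the estimated value is 70000 nM. The expected range for compound 4 runs from 30000 nM to 150000 nM.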

Compound 4, half-maximal inhibitory concentration: 38200 nM
The estimate for compound 4 lay 1.8-fold (0.26 log units) above the measured number; the range from low to high includes it.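

In this assay, among these compounds, bromo in place of methyl on the aromatic carbon para to a large group gives a 2.1-fold lower number from compound 3 to compound 4 (0.33 log units; beyond the scatter), the first step in this set with a true number at both ends and a size beyond the scatter. The earlier compounds shown here offered only floors within the scatter at this place, such as an at least 1.8-fold lower number from compound 1 to compound 3 (0.26 log units; that floor lies within the scatter), whereas bromo in place of hydrogen gives an at least 3.9-fold lower number from compound 1 to compound 4 (0.59 log units; beyond the scatter), a floor that already lies beyond it, and the broader exchange of the whole aryl group gives an at least 3.9-fold lower number from compound 2 to compound 4 (0.59 log units; beyond the scatter). Those last two sizes remain floors because compound 1 and compound 2 each stand at a limit rather than a number: the limit of > 150000 nM in this assay, at which 2 of the 4 values shown sit.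

The compounds shown compare only hydrogen, methyl and bromo at this place, so it remains open whether fluoro, methoxy, an amine or a carboxylic acid there would give a lower number, a higher one or no readable change. From the compounds shown here alone, it also remains open what bromo would do on another carbon of that six-membered aromatic ring, or whether the step from methyl to bromo would keep its size on a different core.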